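Cyclising the amine chain on a glycation receptor antagonist

The source may hold more compounds than are shown below. What is called first, only, known or untested is meant among the compounds shown, and "the series" means these compounds.

Measured so far:
- compound 1, `CCCCc1sc(-c2ccc(Oc3ccc(Cl)cc3)cc2)nc1-c1ccc(OCCCN(CC)CC)cc1`: 57%
- compound 2, `CCCCc1nc(-c2ccc(Oc3ccc(Cl)cc3)cc2)sc1-c1ccc(OCCCN(CC)CC)cc1`: 57.1%

Compound 1 and compound 2 share the same core and differ only in how its two aryl arms are arranged. For the measured compounds named here, in an assay on isolated protein for antagonist activity at advanced glycosylation end product-specific receptor (Homo sapiens), read by ELISA, with a stated time of 60 min, tested at 10 uM (a higher number here means more inhibition at the concentration tested (going by the name of the read-out), a lower number less inhibition), compound 1 gives 57% and compound 2 gives 57.1%; the two numbers lie within the scatter of each other, so neither can be placed ahead of the other, and compound 1 simply sits at the same level as its only neighbour.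

Compound 3, `CCCCc1sc(-c2ccc(Oc3ccc(Cl)cc3)cc2)nc1-c1ccc(OCC2CCCN(CC)C2)cc1`, keeps the core of compound 1 and changes the basic side chain: 1-ethylpiperidin-3-yl in place of 2-(diethylamino)ethyl on a saturated chain carbon bound to an oxygen on an aromatic ring. Going by the values given here, no pair among the measured compounds shows this kind of change, so there is no measured step to lean on. A ring closed onto an otherwise similar chain is expected to shift this assay only modestly, in either direction or not beyond the scatter at all. For compound 3 a value of 52% is estimated, within 30% to 72%, meaning an expected step of a number 5 percentage points lower from compound 1 to compound 3 (within the scatter).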

Compound 3, a percentage reported as inhibition, at one concentration (the size of the read-out at that concentration, not a potency): 55.9%
Compound 3: the middle estimate sits 3.9 percentage points below what was measured, within the range that was stated.
By their numbers in this assay, from the lowest: compounds 3, 1 and 2 (each within the scatter of the next).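

Replacing 2-(diethylamino)ethyl with 1-ethylpiperidin-3-yl on a saturated chain carbon bound to an oxygen on an aromatic ring gives, in this assay, a number 1.1 percentage points lower from compound 1 to compound 3 (within the scatter). For the compounds shown here, the earlier pair varied only how the two aryl arms are arranged, so this is the first measured step at the side chain, and it shows that the open chain and the ring cannot be told apart in this read-out. No supporting measurement is available to explain this result.

The compounds shown leave open whether the reading would hold with a morpholine ring, a dimethylamino group or a carboxylic acid in place of 2-(diethylamino)ethyl. They also leave open whether 1-ethylpiperidin-3-yl would read the same on the arrangement of compound 2.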